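From 2-fluorophenyl to 4-(trifluoromethyl)phenyl

The compounds below may be only part of what the source reports. "The series", "measured", "known", "first", "only" and "open" are said of these compounds alone.

In a functional assay on T47D cells (Homo sapiens) for inhibition, read by CCK-8 assay, with a stated time of 72 h, tested at 10 uM (a higher number here means more inhibition of growth at the concentration tested, a lower number less inhibition of growth), compound 1 `CN(C)C(=O)c1cc2cnc(Nc3ccc(N)cn3)nc2n1C1CCCC1` gives 61.1%, while compound 2 `CN(C)C(=O)c1cc2cnc(Nc3ccc(NC(=O)C4(C(=O)Nc5ccccc5F)CC4)cc3)nc2n1C1CCCC1` gives 97.8%, the higher of the two numbers and clearly beyond the scatter. Compound 3 `CN(C)C(=O)c1cc2cnc(Nc3ccc(NC(=O)C4(C(=O)Nc5ccc(C(F)(F)F)cc5)CC4)cc3)nc2n1C1CCCC1` carries 4-(trifluoromethyl)phenyl in place of 2-fluorophenyl on an amide-type nitrogen. Going by the values given here, no measured pair yet shows what such a swap does. Compound 2 at 97.8% has little room left to rise. The expected change is a small fall within the scatter, an estimated a number 7.8 percentage points lower from compound 2 to compound 3 (within the scatter). The estimate for compound 3 is 90%, with an expected range of 72% to 100%.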

Compound 3, percent growth inhibition at one concentration: 94.9%
Estimate against measurement, compound 3: 4.9 percentage points below; low and high end bracket the measured number.
By their numbers in this assay, from the lowest: compound 1; then compounds 3 and 2 (each within the scatter of the next).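

Measured in this assay the swap to 4-(trifluoromethyl)phenyl gives a number 2.9 percentage points lower from compound 2 to compound 3 (within the scatter) and so shows that this amide-type nitrogen can carry the larger group, with 10 heavy atoms instead of 7, without a readable loss. Both compounds sit near the top of the scale, so a real difference between them could stay hidden at this single concentration. Nothing available here explains the result.

From the compounds shown here alone, whether an aromatic ring is needed on this nitrogen remains open, and a cyclohexyl group or a longer alkyl chain there would test that. Going by these compounds, how compound 2 and compound 3 compare at lower concentrations also remains open.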